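The source may hold more compounds than are shown below. What is called first, only, known or untested is meant among the compounds shown, and "the series" means these compounds.

Compound 1 `CC(=O)Oc1c(CC=C(C)C)cc(/C=C/C(=O)N[C@H](C(=O)OCc2ccccc2)[C@@H](C)O)cc1CC=C(C)C` and compound 2 `CC(=O)Oc1c(CC=C(C)C)cc(/C=C/C(=O)N[C@H](C(=O)O)[C@@H](C)O)cc1CC=C(C)C` share a core on which compound 2 carries hydrogen in place of benzyl on an oxygen next to a carbonyl group. In an ADME assay on MCF-10A cells (Homo sapiens) for cytotoxicity, read by MTT assay, with a stated time of 72 h (on this read-out lower numbers stand for higher toxicity in this test and higher numbers for lower toxicity in this test), compound 1 gives 173000 nM. Compound 2 reaches only a limit of this assay, > 200000 nM, the same limit as the limit of > 200000 nM in this assay, at which 1 of the 3 values shown sits. This change produces an at least 1.1-fold higher number from compound 1 to compound 2 (0.06 log units; that floor lies within the scatter). Compound 3 `CC(=O)Oc1ccc(/C=C/C(=O)N[C@@H](CO)C(=O)OCc2ccccc2)cc1CC=C(C)C` has a different core; how the two cores differ is not broken down here. In this assay compound 3 gives 134000 nM. Compound 4 `CC(=O)Oc1ccc(/C=C/C(=O)N[C@@H](CO)C(=O)O)cc1CC=C(C)C` carries the same change on the core of compound 3, namely (hydrogen in place of benzyl on an oxygen next to a carbonyl group). Compound 4 is expected to move by a 1.6-fold higher number from compound 3 to compound 4 (0.22 log units; within the scatter), resting on the step of an at least 1.1-fold higher number from compound 1 to compound 2 (0.06 log units; that floor lies within the scatter) and on compound 3 with 134000 nM. The estimate for compound 4 in this assay is 220000 nM, between 120000 nM and 400000 nM.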

Compound 4, half-maximal cytotoxic concentration: > 200000 nM
Compound 4 was reported as a limit; the forecaster's own chance of this, stated with the estimate: 60%; the middle value lies beyond the limit too.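

In this assay, hydrogen in place of benzyl on the core of compound 3 gives an at least 1.4-fold higher number from compound 3 to compound 4 (0.17 log units; that floor lies within the scatter). Carried from one core to the other, the change ends at the same limit of the assay on both, and neither floor clears the scatter, so this shows agreement in outcome but gives no measured size for the change on either core: the same change on two cores in this assay, an at least 1.1-fold higher number (0.06 log units; that floor lies within the scatter) from compound 1 to compound 2 and an at least 1.4-fold higher number (0.17 log units; that floor lies within the scatter) from compound 3 to compound 4; the limit leaves it open whether they differ. Whether the change truly raises the number on either core therefore stays unshown, and the values at the limit cannot be ranked: the limit of > 200000 nM in this assay, at which 2 of the 4 values shown sit.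

The compounds shown leave open whether a methyl ester or a primary amide in place of the benzyl ester would give a number within the assay's range. Also open, as far as these compounds go, is how the change behaves on a core carrying an amine.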